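The compounds below may be only part of what the source reports. "The series", "measured", "known", "first", "only" and "open" are said of these compounds alone.

Among the compounds with values here, in an assay on isolated protein for inhibition of histone deacetylase 4 (Homo sapiens), with a stated time of 1 h (a higher number here means a weaker inhibitor, a lower number a stronger inhibitor), compound 1 `O=C(COc1ccc2cc(/C=C3/SC(=O)NC3=O)ccc2c1)Nc1ccc(F)cc1` gives 1600 nM, the highest of the three numbers measured so far, though all three sit close together. Compound 2 `Cc1cccc(NC(=O)COc2ccc3cc(/C=C4/SC(=O)NC4=O)ccc3c2)n1` gives 1100 nM and compound 3 `Cc1cccc2sc(NC(=O)COc3ccc4cc(/C=C5/SC(=O)NC5=O)ccc4c3)nc12` gives 1200 nM. The change from compound 1 to compound 4 `COc1ccc(NC(=O)COc2ccc3cc(/C=C4/SC(=O)NC4=O)ccc3c2)cc1` is methoxy in place of fluoro on an aromatic carbon. Within the data shown here, no measured step swaps one small group on this ring for another; the nearest comparisons replace the whole group on the amide-type nitrogen, with a 1.5-fold lower number from compound 1 to compound 2 (0.16 log units; within the scatter) and a 1.3-fold lower number from compound 1 to compound 3 (0.12 log units; within the scatter), both within the scatter. That end of the shared core has so far accepted change without a shift beyond the scatter, so compound 4 is expected to stay close to compound 1. The estimate for compound 4 is 1500 nM, within 700 nM to 3200 nM, which means an expected 1.1-fold lower number from compound 1 to compound 4 (0.03 log units; within the scatter).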

Compound 4, half-maximal inhibitory concentration: 4700 nM
For compound 4 the middle estimate is 3.1-fold (0.50 log units) below the measured one; the whole stated range lies below it.
By their numbers in this assay, from the lowest: compounds 2, 3 and 1 (each within the scatter of the next); then compound 4.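

In this assay, swapping one small group on the ring carbon para to a large group moves the number beyond the scatter (a 2.9-fold higher number from compound 1 to compound 4 (0.47 log units; beyond the scatter)), whereas the earlier replacements of the whole group on the amide-type nitrogen did not. This end of the molecule is therefore less tolerant than those compounds suggested, and methoxy here gives a weaker inhibitor. Compound 4 also stands apart from the other two (a 3.9-fold higher number from compound 3 to compound 4 (0.59 log units; beyond the scatter); a 4.3-fold higher number from compound 2 to compound 4 (0.63 log units; beyond the scatter)).

Nothing available explains this rise. As far as these compounds go, how a methyl, a hydroxy or an amine on the same carbon would compare remains open.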